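Methoxy for cyano on the chain carbon of compound 2

The compounds below may be only part of what the source reports. "The series", "measured", "known", "first", "only" and "open" are said of these compounds alone.

In a functional assay on MES-SA cells (Homo sapiens) for cytotoxicity, read by luminescence and CellTiter-Glo, with a stated time of 72 h (on this read-out higher numbers stand for weaker inhibition and lower numbers for stronger inhibition), compound 1 (`COC[C@H](NC(=O)c1cc(C)on1)C(=O)N[C@@H](CC1CCCCC1)C(=O)N[C@@H](CC(C)C)C(=O)[C@@]1(C)CO1`) gives 353 nM and compound 2 (`COC[C@H](NC(=O)c1cc(C)on1)C(=O)N[C@@H](CC#N)C(=O)N[C@@H](CC(C)C)C(=O)[C@@]1(C)CO1`) gives 941 nM. Going by the values given here, compound 2 thus holds the higher of the two numbers so far, the weaker inhibition of the pair.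

Compound 3 (`COC[C@H](NC(=O)c1cc(C)on1)C(=O)N[C@@H](COC)C(=O)N[C@@H](CC(C)C)C(=O)[C@@]1(C)CO1`) has methoxy in place of cyano on a saturated chain carbon, two bonds along the chain from an amide-type nitrogen and a carbonyl carbon. The same difference reads cyanomethyl to methoxymethyl.

Among the compounds with values here, one measured step bears on this place: a 2.7-fold higher number from compound 1 to compound 2 (0.43 log units; beyond the scatter), a modest change that put cyano in place of cyclohexyl. That exchange removed a ring, whereas neither group in the present exchange carries one. Within the data shown here, no measurement yet compares methoxy with cyano directly, so the guidance is thin. A smaller effect than that modest step is expected in this assay, with no firm direction. The expected step is a 1.2-fold lower number from compound 2 to compound 3 (0.07 log units; within the scatter), which would not stand beyond the scatter. For compound 3 the estimated value is 800 nM, with an expected range of 350 nM to 1900 nM.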

Compound 3, half-maximal inhibitory concentration: 145 nM
Beside the measured number, compound 3's estimate is 5.5-fold (0.74 log units) above it; measured number below the stated range.
By their numbers in this assay, from the lowest: compound 3; then compound 1; then compound 2.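

In this assay, the step of a 6.5-fold lower number from compound 2 to compound 3 (0.81 log units; beyond the scatter) shows that this chain carbon separates two groups that match in heavy-atom and hydrogen-bond acceptor counts, so those counts alone do not fix the number at this place. Methoxy also reads lower than the ring-bearing cyclohexyl, with a 2.4-fold lower number from compound 1 to compound 3 (0.39 log units; beyond the scatter), which puts compound 1 between the two ringless compounds; among these three, the order at this position therefore does not follow the presence of a ring. Nothing at hand explains the gap between methoxy and cyano.

Still open, as far as these compounds go, is whether the oxygen of methoxy matters in itself or whether any non-nitrile group of this length would read the same: an ethyl group or a hydroxyl on the same chain carbon would separate those two readings. Also open, from the compounds shown here alone, is how far the trend runs along this side chain, since a longer ether chain such as ethoxymethyl or an amine at this place could read either way in this assay.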